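Thiophene to Thiazole on the Ether Chain

A few compounds are considered here, and "the series" means these few. Any claim that something is new, unique, unknown or untested is made for them only; others in the source may bear on it.

Compound 2 `Cc1ccc(CCOc2ccc(-c3c(C)nc(C)c([C@H](OC(C)(C)C)C(=O)O)c3N3CCC(C)(C)CC3)cc2)s1` carries a 5-methylthiophen-2-yl group on the short ether chain. In an ADME assay on microsomes from liver (Rattus norvegicus) for metabolic stability, read by LC-MS, tested at 0.5 uM (a higher number here means that the compound lasts longer, a lower number that the compound disappears faster), compound 2 gives > 2 h, which is a limit of the assay and not a number. Compound 1 `Cc1nc(C)c([C@H](OC(C)(C)C)C(=O)O)c(N2CCC(C)(C)CC2)c1-c1ccc(OCCCc2ccc(F)cc2)cc1`, the 4-fluorobenzyl counterpart, gives > 2 h, also a limit. The step that the two limits leave unreadable from compound 1 to compound 2 stays unreadable because both values sit at the limit of > 2 h in this assay, at which 2 of the 2 values shown sit. Compound 3 `Cc1nc(CCOc2ccc(-c3c(C)nc(C)c([C@H](OC(C)(C)C)C(=O)O)c3N3CCC(C)(C)CC3)cc2)cs1` differs from compound 2 by 2-methyl-1,3-thiazol-4-yl in place of 5-methylthiophen-2-yl on a saturated chain carbon, two bonds along the chain from an oxygen on an aromatic ring. With no readable measured step, the expected step is a step that the limit leaves unreadable from compound 2 to compound 3, nothing beyond the scatter. Compound 3 is estimated at 2.5 h, between 1 h and 4.5 h, most likely reported again only as a limit.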

Compound 3, half-life: 1.75 h
Compound 3: middle estimate off by 1.4-fold (0.15 log units), on the high side; low and high end bracket the measured number.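

In this assay, within the data shown here, compound 3 is the first compound here with a number rather than a limit, so 2-methyl-1,3-thiazol-4-yl gives this position a readable value. The change reads as an at least 1.1-fold lower number from compound 2 to compound 3 (0.05 log units; that floor lies within the scatter), and against the 4-fluorobenzyl counterpart as an at least 1.1-fold lower number from compound 1 to compound 3 (0.05 log units; that floor lies within the scatter), so no real drop is shown. Neither step can be sized further because the other two values are limits: the limit of > 2 h in this assay, at which 2 of the 3 values shown sit.

As far as these compounds go, how far compound 1 and compound 2 truly lie from compound 3 stays open. So does whether a pyridin-2-yl group on the same chain would give a number or a limit.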